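Replacing cyclopropyl on the carbonyl carbon of compound 3

A few compounds are considered here, and "the series" means these few. Any claim that something is new, unique, unknown or untested is made for them only; others in the source may bear on it.

Measured in a functional assay on HepG2 cells (Homo sapiens) for inhibition, read by MTT assay, with a stated time of 48 h; a higher number here means a weaker inhibitor, a lower number a stronger inhibitor:
- compound 1 (`COc1cc(-c2nnc(SCc3ccc(C)cc3)n2-c2ccc(N(C)C)cc2)cc(OC)c1OC`): > 60000 nM
- compound 2 (`COc1cc(-c2nnc(SCC(=O)c3ccccc3)n2-c2ccc(N(C)C)cc2)cc(OC)c1OC`): 18900 nM
- compound 3 (`COc1cc(-c2nnc(SCC(=O)C3CC3)n2-c2ccc(N(C)C)cc2)cc(OC)c1OC`): > 60000 nM

Compound 3 gives > 60000 nM, which is a limit and not a number. Compound 1 gives > 60000 nM, which is also only a limit. Compound 3 therefore stands at the limit of > 60000 nM in this assay, at which 2 of the 3 values shown sit, so no exact potency can be read for it.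

Compound 4 (`COc1ccc(NC(=O)CSc2nnc(-c3cc(OC)c(OC)c(OC)c3)n2-c2ccc(N(C)C)cc2)cc1`) has (4-methoxyphenyl)amino in place of cyclopropyl on a carbonyl carbon.

The closest measured change is an at least 3.1-fold higher number from compound 2 to compound 3 (0.50 log units; beyond the scatter), where cyclopropyl replaced phenyl on a carbonyl carbon. The step that the two limits leave unreadable from compound 1 to compound 3 adds nothing usable. Compound 4 restores a six-membered aromatic ring on the carbonyl side, but through an amino link that compound 2 lacks, so the comparison is only partial. A modest move towards a stronger inhibitor is expected, and compound 4 may still stay at the limit.

The expected change is an at least 4.0-fold lower number from compound 3 to compound 4 (0.60 log units; beyond the scatter), towards a lower number. For compound 4 the estimate is 15000 nM, with an expected range from 4000 nM to 50000 nM.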

Compound 4, half-maximal inhibitory concentration: > 60000 nM
Compound 4: no number, only a limit (the forecaster's own chance of this, stated with the estimate: 30%); middle value at least 4.0-fold (0.60 log units) from the limit.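

In this assay compound 4 gives > 60000 nM, which is a limit and not a number. Putting (4-methoxyphenyl)amino on this carbonyl carbon restores a six-membered aromatic ring but not the readable potency of the benzoyl compound, giving an at least 3.1-fold higher number from compound 2 to compound 4 (0.50 log units; beyond the scatter). A six-membered aromatic ring on the carbonyl side is therefore not enough by itself, and the steps linking compound 4 with compound 1 and compound 3 cannot be read, as each joins two limits.

As far as these compounds go, it remains open whether the amino link or the methoxy group makes the difference, which 4-methoxybenzoyl or plain phenylamino on the same carbonyl carbon could separate. Any ranking among the compounds without a number also stays unknown: the limit of > 60000 nM in this assay, at which 3 of the 4 values shown sit.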